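This account rests on a few compounds, and the source may have more. Where it says the series, first, only, none or still open, it means among the compounds named here.

Measured so far:
compound 1 `CN(CCCCc1cn(-c2ccc(F)cc2)c2ccccc12)Cc1cccc(Cl)c1` — 201 nM
compound 2 `CN(CCCc1cn(-c2ccc(F)cc2)c2ccccc12)Cc1cccc(Cl)c1` — 98.9 nM

Two compounds have been run in an assay on liver for displacement of a labelled ligand from Sigma non-opioid intracellular receptor 1 (Rattus norvegicus); a higher number here means a weaker inhibitor, a lower number a stronger inhibitor. Compound 1 gives 201 nM and compound 2 gives 98.9 nM; compound 1 thus holds the higher of the two numbers, and the gap between them lies beyond the scatter, so on these two points compound 2 is the stronger inhibitor. The two share the same core and differ only in the length of the saturated chain that links that core to the amine nitrogen; nothing more can be read from a pair of this size.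

The next compound, compound 3 `Cc1ccc(CN(C)CCCCc2cn(-c3ccc(F)cc3)c3ccccc23)cc1C`, keeps the chain length of compound 1 and changes the group on the other side of the amine: 3,4-dimethylphenyl in place of 3-chlorophenyl on a saturated chain carbon bound to an amine nitrogen. Among the compounds with values here, no measured pair shows this kind of exchange, so there is no step to lean on. Both groups are aromatic, carry no donors or acceptors and are of similar bulk, so in this assay the step from compound 1 to compound 3 is expected to be small, in either direction, and likely within the scatter; the estimate is a 1.0-fold lower number from compound 1 to compound 3 (0.00 log units; within the scatter). For compound 3 the expected value in this assay is 200 nM, with a range of 70 nM to 600 nM.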

Compound 3, inhibition constant: 20.8 nM
Compound 3: the middle estimate sits 9.6-fold (0.98 log units) above what was measured; measured number below the stated range.
By their numbers in this assay, from the lowest: compound 3; then compound 2; then compound 1.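

In this assay the aryl group on the benzyl side of the amine proves to be a sensitive position: 3,4-dimethylphenyl in place of 3-chlorophenyl on a saturated chain carbon bound to an amine nitrogen gives a 9.7-fold lower number from compound 1 to compound 3 (0.99 log units; beyond the scatter). The two groups match in ring type and in their lack of hydrogen-bond donors and acceptors, so these shared counts do not tell the two apart, and the step is also wider than the gap in the chain-length pair, where compound 1 gives 201 nM and compound 2 gives 98.9 nM. Within the data shown here, nothing available explains why this exchange moves the number so far.

The compounds shown do not separate the contribution of the lost chlorine from that of either added methyl, a question that 3-methylphenyl, 4-methylphenyl, unsubstituted phenyl or 3,4-dichlorophenyl on the same chain would address. As far as these compounds go, it also remains open whether the step from 3-chlorophenyl to 3,4-dimethylphenyl carries over to the shorter chain of compound 2, or to a still shorter or longer chain.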